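The source may report more compounds than this note shows. Statements on the series, on what has been measured and on what is new or still open speak of the compounds shown alone.

Working notes on the series. For the measured compounds named here, compound 2 `CCN1CCN(C(=O)c2cccn2-c2ccc(Nc3ncc(Cl)c(Nc4ccccc4NS(C)(=O)=O)n3)c(OC)c2)CC1` gives 1130 nM in a functional assay on NCI-H2228 cells (Homo sapiens) for antiproliferative activity, read by MTT assay, with a stated time of 72 h (a higher number here means a weaker inhibitor, a lower number a stronger inhibitor), and holds the highest of the two numbers so far; its nearest neighbour is compound 1 `COC(=O)c1cccn1-c1ccc(Nc2ncc(Cl)c(Nc3ccccc3NS(C)(=O)=O)n2)c(OC)c1`, which in this assay gives 950 nM, the step being a 1.2-fold higher number from compound 1 to compound 2 (0.08 log units; within the scatter). Compound 3 `CCN(CC)C(=O)c1cccn1-c1ccc(Nc2ncc(Cl)c(Nc3ccccc3NS(C)(=O)=O)n2)c(OC)c1` is the next member to be measured in this assay. It differs from compound 2 in one place: diethylamino in place of 4-ethylpiperazin-1-yl on a carbonyl carbon. Going by the values given here, the only measured step that bears on this position, a 1.2-fold higher number from compound 1 to compound 2 (0.08 log units; within the scatter), exchanges the groups on the same carbonyl carbon and stays within the scatter, so the amide substituent has so far made no difference beyond the noise. Among the compounds with values here, no measured pair sets a ring amine against an acyclic amine on this carbonyl carbon. The step expected from compound 2 to compound 3 is therefore a 1.1-fold lower number from compound 2 to compound 3 (0.05 log units; within the scatter), none beyond the scatter. For compound 3 the estimate in this assay is 1000 nM, with a range from 450 nM to 2200 nM.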

Compound 3, half-maximal inhibitory concentration: 870 nM
Beside the measured number, compound 3's estimate is 1.1-fold (0.06 log units) above it; low and high end bracket the measured number.
By their numbers in this assay, from the lowest: compounds 3, 1 and 2 (each within the scatter of the next).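

In this assay, an acyclic amine on this carbonyl carbon now stands against a ring amine and against methoxy, with a 1.3-fold lower number from compound 2 to compound 3 (0.11 log units; within the scatter) and with a 1.1-fold lower number from compound 1 to compound 3 (0.04 log units; within the scatter) as the two readings. Giving up the six-membered ring and the second nitrogen of 4-ethylpiperazin-1-yl for diethylamino therefore moves the number no further than the scatter. Methoxy, 4-ethylpiperazin-1-yl and diethylamino cannot be told apart on this carbonyl carbon, and no measurement on hand offers an account of this flat result.

Still open, going by these compounds, is whether a hydroxyl group, giving the free carboxylic acid, or an unsubstituted amino group, giving the primary amide, would also leave the number unchanged on this carbonyl carbon. On these data alone, all three compounds share the rest of the structure, so it is also open whether this flatness would hold with a change elsewhere on the shared core.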